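Fluoro on the phenyl of compound 3

A few compounds are considered here, and "the series" means these few. Any claim that something is new, unique, unknown or untested is made for them only; others in the source may bear on it.

Measured so far in a functional assay on A549 cells (Homo sapiens) for antiproliferative activity, read by MTT assay, with a stated time of 72 h (a lower number here means a stronger inhibitor, a higher number a weaker inhibitor), for this series
- compound 1 `COc1ccc(-c2ncnn2-c2cc(OC)c(OC)c(OC)c2)cc1` gives 520 nM
- compound 2 `COc1cccc(-c2ncnn2-c2cc(OC)c(OC)c(OC)c2)c1` gives > 10000 nM (a limit)
- compound 3 `COc1cc(-n2ncnc2-c2ccccc2)cc(OC)c1OC` gives > 10000 nM (a limit)

Compound 3 gives only a limit (> 10000 nM) and no number. The series shows the limit of > 10000 nM in this assay, at which 2 of the 3 values shown sit, and compound 2 shares it. Compound 4 `COc1cc(-n2ncnc2-c2cccc(F)c2)cc(OC)c1OC` differs by fluoro in place of hydrogen on an aromatic carbon on the phenyl of compound 3, with fluoro in place of hydrogen. Among the compounds with values here, two measured steps touch that phenyl and both are large: an at least 19-fold higher number from compound 1 to compound 2 (1.28 log units; beyond the scatter) and an at least 19-fold higher number from compound 1 to compound 3 (1.28 log units; beyond the scatter) lie beyond the scatter. Also shown is a step that the two limits leave unreadable from compound 2 to compound 3 and no step adds fluoro. Compound 1 alone gives a number (520 nM) and compound 4 lacks its 4-methoxyphenyl. The outcome expected in this assay is a step that the limit leaves unreadable from compound 3 to compound 4 with nothing beyond the scatter. Compound 4 is estimated at 12000 nM (range 4000 nM to 40000 nM) and may well report only a limit.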

Compound 4, half-maximal inhibitory concentration: > 10000 nM
Compound 4 was reported as a limit; the forecaster's own chance of this, stated with the estimate: 75%; the middle value does not contradict the limit.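

In this assay, 3-fluorophenyl in place of 4-methoxyphenyl gives an at least 19-fold higher number from compound 1 to compound 4 (1.28 log units; beyond the scatter). Fluoro on this phenyl thus does not restore a readable number: the result for compound 4 is a limit, and its steps to compound 2 and compound 3 cannot be read. Compound 1 remains the only compound with a number, while the others sit at one limit: the limit of > 10000 nM in this assay, at which 3 of the 4 values shown sit.

Open, on these data alone, is whether an amine, a hydroxyl or a longer alkoxy chain in place of the methoxy of the 4-methoxyphenyl of compound 1 keeps a readable number. Also open, as far as these compounds go, is how compound 2, compound 3 and compound 4 rank among themselves, as all three are limits.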